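The source may report more compounds than this note shows. Statements on the series, on what has been measured and on what is new or still open speak of the compounds shown alone.

The compounds here share one core, seen in compound 1 `Clc1ccc(Cn2cc(CSc3nnc(-c4ccccc4)c(-c4ccccc4)n3)nn2)cc1`, which carries a chloro group. In a functional assay on MGC-803 cells (Homo sapiens) for antiproliferative activity, read by MTT assay, with a stated time of 48 h (a higher number here means a weaker inhibitor, a lower number a stronger inhibitor), compound 1 gives 13200 nM. Compound 2 `Brc1ccc(Cn2cc(CSc3nnc(-c4ccccc4)c(-c4ccccc4)n3)nn2)cc1` carries bromo in place of chloro. In this assay compound 2 reaches only the limit > 100000 nM, so no number is known for it; this is the limit of > 100000 nM in this assay, at which 1 of the 3 values shown sits. Within the data shown here, the one measured step is an at least 7.5-fold higher number from compound 1 to compound 2 (0.87 log units; beyond the scatter). Among the measured compounds shown here, compound 3 `COc1ccc(C(=O)/C=C/c2ccc(-n3cc(CSc4nnc(-c5ccccc5)c(-c5ccccc5)n4)nn3)cc2)cc1` gives 36700 nM in this assay, the highest of the two numbers known, with compound 1 nearest. Compound 4 `NS(=O)(=O)c1ccc(-n2cc(CSc3nnc(-c4ccccc4)c(-c4ccccc4)n3)nn2)cc1` differs from compound 3 by sulfamoyl in place of 2-((4-methoxyphenyl)carbonyl)ethenyl on an aromatic carbon. The measured halogen swap sits elsewhere and does not bear on this change, so no direction is indicated. Compound 4 is therefore expected near 20000 nM, between 5000 nM and 100000 nM, an expected step of a 1.8-fold lower number from compound 3 to compound 4 (0.26 log units; within the scatter) within the scatter.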

Compound 4, half-maximal inhibitory concentration: > 100000 nM
Compound 4 ended at the assay's limit; the forecaster's own chance of this, stated with the estimate: 20%; middle value at least 5.0-fold (0.69 log units) from the limit.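

In this assay, sulfamoyl on this aromatic carbon, para to a large group, does worse than 2-((4-methoxyphenyl)carbonyl)ethenyl, with an at least 2.7-fold higher number from compound 3 to compound 4 (0.43 log units; beyond the scatter). Putting 4-sulfamoylphenyl in place of 4-chlorobenzyl on the aromatic nitrogen gives an at least 7.5-fold higher number from compound 1 to compound 4 (0.87 log units; beyond the scatter), so both readable steps into compound 4 point the same way. The step from compound 2 to compound 4 cannot be read, since each of these compounds stands at a limit and not at a number: the limit of > 100000 nM in this assay, at which 2 of the 4 values shown sit.

On these data alone, whether an amine or a carboxylic acid on this aromatic carbon would give a readable number stays open. As far as these compounds go, how weak compound 4 really is also stays open.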